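A fluoro step from a level pair

The compounds below may be only part of what the source reports. "The series", "measured", "known", "first", "only" and "open" are said of these compounds alone.

compound 1 `COC(=O)CCc1ccc(S(=O)(=O)n2c(C3(O)C=CC(=O)C=C3)cc3ccc(F)cc32)cc1` gives 30 nM
compound 2 `O=C1C=CC(O)(c2cc3ccccc3n2S(=O)(=O)c2ccc(CCC(=O)O)cc2)C=C1` gives 30 nM

In a functional assay on HCT-116 cells (Homo sapiens) for inhibition, read by MTT assay, with a stated time of 72 h (on this read-out higher numbers stand for weaker inhibition and lower numbers for stronger inhibition), compound 1 gives 30 nM and compound 2 gives 30 nM at the digits shown, so compound 2 stands level with compound 1 within the scatter. Compound 3 `O=C1C=CC(O)(c2cc3ccc(F)cc3n2S(=O)(=O)c2ccc(CCC(=O)O)cc2)C=C1` has not yet been measured. It is compound 2 with fluoro in place of hydrogen on an aromatic carbon of a six-membered aromatic ring of carbon only, part of a fused or bridged system of two rings. For the measured compounds named here, no measured pair isolates this change, so the data offer no step to lean on. In this assay no step beyond the scatter is expected, and the expectation starts from compound 2 at 30 nM in this read-out. The expected step is no change at the digits printed from compound 2 to compound 3 (within the scatter) as an estimate only. For compound 3 the estimated value is 30 nM with an expected range of 12 nM to 75 nM in this measurement.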

Compound 3, half-maximal inhibitory concentration: 30 nM
Estimate against measurement, compound 3: no gap at the digits printed; the range from low to high includes it.
By their numbers in this assay, from the lowest: compounds 1, 2 and 3 (each within the scatter of the next).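

In this assay, fluoro in place of hydrogen on an aromatic carbon, meta to a fused ring and para to a fused ring, can now be read alone, and the step is no change at the digits printed from compound 2 to compound 3 (within the scatter). With the fluoro held in place, hydrogen in place of methyl on an oxygen next to a carbonyl group can also be read alone, and that step is no change at the digits printed from compound 1 to compound 3 (within the scatter); the earlier pair differed in both places at once, so neither change could be separated there. Nothing in the data shown offers an explanation for either reading.

Going by these compounds, whether a chloro or a methoxy group on the same aromatic carbon would stand level as well remains open. So does the outcome of an amide in place of the carboxylic acid, or of a longer chain carrying that acid.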